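A Smaller Ring on the Aromatic Nitrogen

The compounds below may be only part of what the source reports. "The series", "measured", "known", "first", "only" and "open" are said of these compounds alone.

Three compounds measured in a functional assay on RAW264.7 cells (Mus musculus) for inhibition, read by Griess assay, with stated times of 2 h and 24 h (a higher number here means a weaker inhibitor, a lower number a stronger inhibitor), share one core and differ only in the group on an aromatic nitrogen of a five-membered aromatic ring with 3 nitrogen. Compound 1 `COc1ccc([C@@H]2CC(=O)c3c(O)cc(OCc4cn(Cc5cccc(C(F)(F)F)c5)nn4)cc3O2)cc1O` carries a 3-(trifluoromethyl)benzyl there and gives 19900 nM. Compound 2 `CCn1cc(COc2cc(O)c3c(c2)O[C@H](c2ccc(OC)c(O)c2)CC3=O)nn1` carries an ethyl and gives 15000 nM. Compound 3 `COc1ccc([C@@H]2CC(=O)c3c(O)cc(OCc4cn(C5CCCC5)nn4)cc3O2)cc1O` carries a cyclopentyl and gives 10500 nM, the lowest of the three numbers, although the steps of a 1.9-fold lower number from compound 1 to compound 3 (0.28 log units; within the scatter) and a 1.4-fold lower number from compound 2 to compound 3 (0.15 log units; within the scatter) both stay within the scatter, as does a 1.3-fold lower number from compound 1 to compound 2 (0.12 log units; within the scatter). Compound 3 therefore cannot be called the strongest inhibitor; the three numbers sit together.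

Compound 4 `COc1ccc([C@@H]2CC(=O)c3c(O)cc(OCc4cn(CC5CC5)nn4)cc3O2)cc1O` is the next step from compound 3: cyclopropylmethyl in place of cyclopentyl on an aromatic nitrogen. Going by the values given here, the steps that bear on it are the two earlier changes at the same aromatic nitrogen, a 1.4-fold lower number from compound 2 to compound 3 (0.15 log units; within the scatter) and a 1.9-fold lower number from compound 1 to compound 3 (0.28 log units; within the scatter). Neither an ethyl nor a 3-(trifluoromethyl)benzyl moved the number beyond the scatter relative to a cyclopentyl, so a cyclopropylmethyl at the same place is expected to leave it there as well. The expected step is a 1.1-fold higher number from compound 3 to compound 4 (0.06 log units; within the scatter), no change beyond the scatter in either direction. Compound 4 is estimated to give 12000 nM in this assay, with a range from 5000 nM to 30000 nM.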

Compound 4, half-maximal inhibitory concentration: 11900 nM
Compound 4: middle estimate off by 1.0-fold (0.00 log units), on the high side; measured number inside the range.
By their numbers in this assay, from the lowest: compounds 3, 4, 2 and 1 (each within the scatter of the next).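

In this assay the change from cyclopentyl to cyclopropylmethyl on the aromatic nitrogen gives a 1.1-fold higher number from compound 3 to compound 4 (0.05 log units; within the scatter) and so replaces a five-membered non-aromatic ring of carbon with a three-membered one on a methyl-linked group without separating compound 4 from compound 3. Compound 4 also stays within the scatter of the two other groups at this position, with a 1.3-fold lower number from compound 2 to compound 4 (0.10 log units; within the scatter) and a 1.7-fold lower number from compound 1 to compound 4 (0.22 log units; within the scatter) as its steps, so none of the four groups shown, from ethyl to 3-(trifluoromethyl)benzyl, stands apart from the others in this read-out. Nothing among the data shown gives a reason why the number stays together across these four groups.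

On these data alone, whether an amine, a carboxylic acid or a longer chain such as hexyl on the same aromatic nitrogen would move the number beyond the scatter remains open. All four compounds also keep the shared core unchanged, so what a change elsewhere on it would do in this assay is left open as well.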